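Vero cytotoxicity notes: amino replaces trifluoromethyl

The source may hold more compounds than are shown below. What is called first, only, known or untested is meant among the compounds shown, and "the series" means these compounds.

Two compounds of the series carry measurements: compound 1 `O=c1[nH]c(N2CCCCC2)nc2cc(Cl)ccc12` and compound 2 `O=c1[nH]c(Nc2cc(F)cc(F)c2)nc2cc(C(F)(F)F)ccc12`. In an ADME assay on Vero cells (Chlorocebus sabaeus) for cytotoxicity, read by WST assay (a lower number here means that less compound is tolerated, a higher number that more compound is tolerated), compound 1 gives > 25000 nM, which is a limit of the assay and not a number. Compound 2 gives >= 7600 nM in this assay, also a limit rather than a number. Within the data shown here, compound 2 therefore stands only on a limit, as does the one other value shown (the limit of > 25000 nM in this assay, at which 1 of the 2 values shown sits; (the limit of >= 7600 nM in this assay, at which 1 of the 2 values shown sits)), and no sized step between the two can be drawn from them.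

Compound 3 `Nc1ccc2c(=O)[nH]c(Nc3cc(F)cc(F)c3)nc2c1` has not yet been measured. It differs from compound 2 by amino in place of trifluoromethyl on an aromatic carbon. Among the measured compounds shown here, no measured pair shows this change, so its size is unknown. Both measured compounds sit at limits in this assay; the working expectation is no step beyond the scatter in either direction. Compound 3 is expected to give 15000 nM, within a range from 5000 nM to 50000 nM. The step from compound 2 to compound 3 is expected to be a step that the limit leaves unreadable from compound 2 to compound 3.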

Compound 3, half-maximal cytotoxic concentration: > 25000 nM
Compound 3: no number, only a limit; the forecaster's own chance of this, stated with the estimate: 70%; middle value at least 1.6-fold (0.22 log units) from the limit.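

Compound 2 and compound 3 both stand only on limits in this assay, so the step for amino in place of trifluoromethyl on an aromatic carbon cannot be read between them. The compounds shown leave open whether this change moves the tolerated concentration in this assay at all, and in which direction.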